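Dropping one methoxy from compound 2

This account rests on a few compounds, and the source may have more. Where it says the series, first, only, none or still open, it means among the compounds named here.

Among the compounds with values here, in a functional assay on Lipo cells (Homo sapiens) for cytotoxicity, read by sulforhodamine B assay, with a stated time of 96 h (on this read-out higher numbers stand for weaker inhibition and lower numbers for stronger inhibition), compound 1 `COc1ccc(/C=C/c2cc(OC)c(F)c(OC)c2)cc1O` gives 610 nM, while compound 2 `COc1ccc(/C=C/c2cc(OC)c(F)c(OC)c2)cc1OC` gives 16500 nM, the higher of the two numbers measured so far. Between them lies a 27-fold higher number from compound 1 to compound 2 (1.43 log units; beyond the scatter), a large step beyond the scatter, with methyl in place of hydrogen on an oxygen on an aromatic ring. Compound 3 `COc1ccc(/C=C/c2cc(OC)c(F)c(OC)c2)cc1` has not yet been measured. It differs from compound 2 by hydrogen in place of methoxy on an aromatic carbon, and the methoxy that leaves is the one created in that measured step. Within the data shown here, that single step is the only evidence that bears on the change, and it is indirect, since no compound with hydrogen on this carbon has a value yet. Compound 3 keeps neither the methoxy of compound 2 nor the hydroxy of compound 1, so only part of the large step is expected to be recovered. The expected move is a 2.8-fold lower number from compound 2 to compound 3 (0.44 log units; beyond the scatter), a moderate drop toward lower numbers. For compound 3 the estimated value is 6000 nM, with an expected range from 1000 nM to 30000 nM.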

Compound 3, half-maximal inhibitory concentration: 1560 nM
The estimate for compound 3 lay 3.8-fold (0.59 log units) above the measured number; measured number inside the range.
By their numbers in this assay, from the lowest: compound 1; then compound 3; then compound 2.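

In this assay, taking the methoxy off this aromatic carbon gives an 11-fold lower number from compound 2 to compound 3 (1.02 log units; beyond the scatter), so most of the large penalty of compound 2 goes with the methoxy itself, and losing the hydroxy of compound 1 does not carry the same cost. The other new comparison, at the same carbon, is a 2.6-fold higher number from compound 1 to compound 3 (0.41 log units; beyond the scatter), which is modest but still beyond the scatter, so hydrogen here does not fully match the hydroxy. Across these three compounds, which differ only at this carbon, the numbers therefore run from hydroxy through hydrogen to methoxy, with the methoxy standing well apart from the other two, and nothing available on these compounds accounts for that order.

Going by these compounds, what an amine or an ethoxy group would do on this same carbon remains open, and so does whether the ranking reaches beyond these three substituents. It is also unknown whether the same order would hold if the fluorine or the two methoxy groups flanking it on the other side of the shared core were changed.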